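A few compounds are considered here, and "the series" means these few. Any claim that something is new, unique, unknown or untested is made for them only; others in the source may bear on it.

Compound 1 `CN1CCN(c2ccc(Nc3ncc(/N=C/c4ccc(C(F)(F)F)cc4)c(NC4CCCC4)n3)cc2)CC1` is tested in a functional assay on HCT-116 cells (Homo sapiens) for antiproliferative activity, read by MTT assay; on this read-out higher numbers stand for weaker inhibition and lower numbers for stronger inhibition. In that test compound 1 gives only a limit, > 100000 nM, and not a number. Its result sits at the limit of > 100000 nM in this assay, at which 1 of the 2 values shown sits, the upper edge of what the test reports. A second compound, compound 2 `CCOC(=O)/C=N/c1cnc(Nc2ccc(S(N)(=O)=O)cc2)nc1NC1CCCC1`, also carries a sulfamoyl group, and in this assay compound 2 gives 9640 nM. Compound 3 `NS(=O)(=O)c1ccc(Nc2ncc(/N=C/c3ccc(C(F)(F)F)cc3)c(NC3CCCC3)n2)cc1` keeps the core of compound 1 with sulfamoyl in place of 4-methylpiperazin-1-yl on an aromatic carbon. Going by the values given here, no measured pair shows this exact change, so the step from compound 1 to compound 3 is expected to move toward stronger inhibition, an at least 16-fold lower number from compound 1 to compound 3 (1.22 log units; beyond the scatter). Compound 3 is estimated at 6000 nM, between 1500 nM and 40000 nM.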

Compound 3, half-maximal inhibitory concentration: > 100000 nM
Compound 3: no number, only a limit; the forecaster's own chance of this, stated with the estimate: 25%; middle value at least 16-fold (1.22 log units) away from the limit.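

In this assay compound 3 gives > 100000 nM, which is a limit and not a number. With sulfamoyl kept, 4-(trifluoromethyl)phenyl in place of ethoxycarbonyl gives an at least 10-fold higher number from compound 2 to compound 3 (1.01 log units; beyond the scatter), so sulfamoyl alone does not secure a measurable value in this assay. The step between compound 1 and compound 3 cannot be read, because both stand at the same limit: the limit of > 100000 nM in this assay, at which 2 of the 3 values shown sit.

From the compounds shown here alone, it stays open whether sulfamoyl and 4-methylpiperazin-1-yl differ when ethoxycarbonyl is present. Also open, going by these compounds, is how a carboxylic acid or a primary amide in place of ethoxycarbonyl would behave.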